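A few compounds are considered here, and "the series" means these few. Any claim that something is new, unique, unknown or untested is made for them only; others in the source may bear on it.

Of the compounds shown here, three have been tested in an assay on cells with Cystic fibrosis transmembrane conductance regulator variant F508del (Homo sapiens) as the target, read by fluorescence, with stated times of 24 h and 30 min; a higher number here means that more compound is needed for the effect, a lower number that less compound is needed. Compound 1 `NC(=O)CN1CCN(c2nc(-c3cccnc3)nc3c2CN(Cc2ccccc2)CC3)CC1` gives 100000 nM there. Compound 3 `Cc1cc(C)c2cc(C#N)c(N3CCN(C(=O)c4ccccn4)CC3)nc2c1` gives 100000 nM, level with compound 1 at the digits shown, and together these two stand at the highest number of the three. Compound 2 `Cc1cc(C)c2cc(C#N)c(NCCCNC(=O)c3ccncc3)nc2c1` gives 13200 nM, a clearly lower number than compound 1, so compound 2 needs less material for the same effect. Nothing is known about any single-point step between these three compounds, so only their bare values can be compared.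

The next compound keeps the core of compound 1 and alters one group: compound 4 `CN(C)CCN1CCN(c2nc(-c3cccnc3)nc3c2CN(Cc2ccccc2)CC3)CC1` differs from compound 1 by (dimethylamino)methyl in place of carbamoyl on a saturated chain carbon bound to an amine nitrogen in a ring. No change of this kind has been measured on this series. With compound 1 standing at 100000 nM in this assay, there is room for a lower number but no measured guide to it. The expected step from compound 1 to compound 4 is a 1.7-fold lower number from compound 1 to compound 4 (0.22 log units; within the scatter), a modest move toward a lower number, if any beyond the scatter. Compound 4 is therefore estimated at 60000 nM, with a range from 15000 nM to 100000 nM.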

Compound 4, half-maximal effective concentration: 100000 nM
Compound 4: the middle estimate sits 1.7-fold (0.22 log units) below what was measured; the measured number falls inside the stated range.
By their numbers in this assay, from the lowest: compound 2; then compounds 1, 3 and 4 (each within the scatter of the next).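

The first step measured at this position, (dimethylamino)methyl in place of carbamoyl on a saturated chain carbon bound to an amine nitrogen in a ring, shows no change at the digits printed from compound 1 to compound 4 (within the scatter) in this assay. The leaving group carries a hydrogen-bond donor and the entering group carries none, yet this exchange, which also adds one heavy atom, leaves the number where it was. No measurement at hand bears on why the number stays the same.

As far as these compounds go, it remains open whether a carboxylic acid, a hydroxyl group or a longer chain in this place would bring the number down. From the compounds shown here alone, it is also open whether any group at this position can move the number at all while the rest of compound 1 stays unchanged.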